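The compounds below may be only part of what the source reports. "The series", "measured", "known", "first", "only" and "open" are said of these compounds alone.

Going by the values given here, in a functional assay on MIA cells (Homo sapiens) for inhibition, read by MTT assay, with a stated time of 72 h (on this read-out lower numbers stand for stronger inhibition of growth and higher numbers for weaker inhibition of growth), compound 2 `COc1ccc(CNC(=O)/C(C#N)=C/c2ccc(C)o2)cc1` gives 51000 nM, and it is the one compound among the three measured whose result is a number rather than a limit. Compound 1 `N#C/C(=C\c1ccco1)C(=O)NCc1ccc(Cl)c(Cl)c1` reaches only a limit of this assay, > 50000 nM. Compound 3 `COc1ccc(CNC(=O)/C(C#N)=C/c2ccc(-c3ccccc3)o2)cc1` likewise reaches only a limit of this assay, > 100000 nM. Among the compounds with values here, the one measured step that alters the furan part of the shared core, an at least 1.9-fold higher number from compound 2 to compound 3 (0.29 log units; that floor lies within the scatter), ends at the limit of > 100000 nM in this assay, at which 1 of the 3 values shown sits, and so shows no more than a floor for how far the number rose.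

Compound 4 `COc1ccc(CNC(=O)/C(C#N)=C/c2cc(Br)co2)cc1` is the compound still to be measured; it differs from compound 2 in one place, (4-bromofuran-2-yl in place of 5-methylfuran-2-yl on a double-bonded chain carbon bound to a double-bonded chain carbon). Within the data shown here, no measured step introduces a bromine, and the only measured step on the furan is itself cut off by a limit. Among the measured compounds shown here, the expectation for compound 4 therefore rests on compound 2 alone, whose 51000 nM is the sole number available. Compound 4 is expected to give 60000 nM in this assay, within a range from 20000 nM to 180000 nM. The step this estimate implies, a 1.2-fold higher number from compound 2 to compound 4 (0.07 log units; within the scatter), is expected to stay within the scatter, with a real chance that only a limit is reported.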

Compound 4, concentration for 50% growth inhibition: 65000 nM
Estimate against measurement, compound 4: 1.1-fold (0.03 log units) below, and the stated range covers the measured number.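

In this assay, putting 4-bromofuran-2-yl in place of 5-methylfuran-2-yl gives a 1.3-fold higher number from compound 2 to compound 4 (0.11 log units; within the scatter), so this swap leaves no change that can be told apart from repeat-to-repeat variation, and a bromine is tolerated here as far as this one pair can show. Unlike the earlier furan step, this one has a real number at both ends, whereas compound 3, with its phenyl in place of the methyl, gives only a limit of the assay, > 100000 nM, and so shows no true size for its step. Nothing measured here offers a reason why the swap leaves the number where it is.

From the compounds shown here alone, the names of the two groups show that the swap changes both the substituent and its place on the furan, so the effect of each alone remains unknown. Also open, going by these compounds, is whether a different group on the furan, such as an amine or a carboxylic acid, would shift the number beyond the scatter in either direction.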